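Adding a Methoxy Group to Compound 2: Expected Outcome

The source may hold more compounds than are shown below. What is called first, only, known or untested is meant among the compounds shown, and "the series" means these compounds.

Measured compounds:
Compound 1, `COc1cc(-c2cc(/C=C/C(=O)c3ccc(N)cc3)[nH]n2)cc(OC)c1OC`: 2660 nM
Compound 2, `COc1ccc(C(=O)/C=C/c2cc(-c3cc(OC)c(OC)c(OC)c3)n[nH]2)cc1OC`: 2600 nM
Compound 3, `COc1ccc(-c2cc(/C=C/C(=O)c3ccc(N)cc3)[nH]n2)cc1OC`: 3530 nM

In a functional assay on SF-539 cells (Homo sapiens) for inhibition, read by sulforhodamine B assay, with a stated time of 48 h (a lower number here means a stronger inhibitor of growth, a higher number a weaker inhibitor of growth), compound 3 gives 3530 nM and compound 1 gives 2660 nM. The two differ by one change, (methoxy in place of hydrogen on an aromatic carbon), and the step was a 1.3-fold lower number from compound 3 to compound 1 (0.12 log units; within the scatter). Compound 2 gives 2600 nM in this assay; its core differs from that of compound 3, and the difference between the two cores is not broken down here. The step of a 1.0-fold lower number from compound 1 to compound 2 (0.01 log units; within the scatter) shows the two values side by side.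

Compound 4, `COc1cc(C(=O)/C=C/c2cc(-c3cc(OC)c(OC)c(OC)c3)n[nH]2)cc(OC)c1OC`, has not been measured. It differs from compound 2 by methoxy in place of hydrogen on an aromatic carbon, the same change that was made from compound 3 to compound 1, since the surroundings of the place are described in the same words. Because the earlier step of a 1.3-fold lower number from compound 3 to compound 1 (0.12 log units; within the scatter) stayed within the scatter, the step from compound 2 to compound 4 is expected to be small as well, about a 1.1-fold lower number from compound 2 to compound 4 (0.05 log units; within the scatter). In this assay compound 4 is therefore estimated at 2300 nM, with a likely range from 1100 nM to 4800 nM.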

Compound 4, concentration for total growth inhibition: 2830 nM
Estimate against measurement, compound 4: 1.2-fold (0.09 log units) below; low and high end bracket the measured number.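

In this assay, putting methoxy in place of hydrogen on an aromatic carbon gave a 1.1-fold higher number from compound 2 to compound 4 (0.04 log units; within the scatter). Set beside the same change on the other core, the two steps cannot be told apart: the same change on two cores in this assay, a 1.3-fold lower number (0.12 log units; within the scatter) from compound 3 to compound 1 and a 1.1-fold higher number (0.04 log units; within the scatter) from compound 2 to compound 4, 1.4-fold (0.16 log units) apart, within the scatter of two such steps. This shows that the change made no readable difference on either core in this assay, but two pairs with such small steps cannot show whether a small real effect exists or points the same way on both cores, and they say nothing about other cores or other assays.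

The aromatic substituents shown are limited to methoxy groups and, on compound 1 and compound 3, an amino group, which leaves open how growth inhibition would respond to a different kind of group at this place. A chlorine atom, a hydroxyl group or a longer chain such as ethoxy could show whether this place responds to substitution at all.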